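The source may report more compounds than this note shows. Statements on the series, on what has been measured and on what is new or still open speak of the compounds shown alone.

In a functional assay on WiDr cells (Homo sapiens) for inhibition (a lower number here means a stronger inhibitor, a higher number a weaker inhibitor), compound 1 `N#CC1CN1C(=O)Nc1ccc([N+](=O)[O-])cc1` gives 3700 nM, compound 3 `N#CC1CN1C(=O)Nc1ccc(F)cc1` gives 9000 nM, and compound 2 `CNC(=O)N1CC1C#N` gives 23000 nM. Compound 2 thus has the highest number of the three, separated beyond the scatter from compound 3 and still more from compound 1. Among the measured compounds shown here, the single one-point step measured so far, a 2.4-fold higher number from compound 1 to compound 3 (0.39 log units; beyond the scatter), concerns the aromatic ring, which compound 2 does not carry. Compound 4 `N#CC1CN1C(N)=O` differs from compound 2 in hydrogen in place of methyl on an amide-type nitrogen. For the measured compounds named here, no measured step touches the amide-type nitrogen, so nothing speaks for a move in this assay beyond the scatter in either direction. Compound 4 is therefore expected to give about 23000 nM, between 8000 nM and 65000 nM. The expected step is no change at the digits printed from compound 2 to compound 4 (within the scatter).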

Compound 4, half-maximal inhibitory concentration: > 280000 nM
Compound 4 was reported as a limit; the forecaster's own chance of this, stated with the estimate: 15%; middle value at least 12-fold (1.08 log units) from the limit.
By their numbers in this assay, from the lowest: compound 1; then compound 3; then compound 2. At a limit, above all of these: compound 4.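

Hydrogen in place of methyl on an amide-type nitrogen gives an at least 12-fold higher number from compound 2 to compound 4 (1.08 log units; beyond the scatter) in this assay, so this position is far from silent, and the change is large where the one measured step on the aromatic ring, a 2.4-fold higher number from compound 1 to compound 3 (0.39 log units; beyond the scatter), was modest. Compound 4 gives > 280000 nM, which is a limit and not a number. The methyl on this nitrogen thus separates a readable value from a limit in this series.

The compounds shown leave open how an ethyl group or a longer chain on this nitrogen would read. On these data alone, a chain ending in an amine at the same place is equally open.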